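Dichlorophthalimide series: pyridinyl isomer on the imide nitrogen

The source may report more compounds than this note shows. Statements on the series, on what has been measured and on what is new or still open speak of the compounds shown alone.

Measured so far:
compound 1, `O=C1c2cc(Cl)c(Cl)cc2C(=O)N1c1ncccn1`, 58%
compound 2, `O=C1c2cc(Cl)c(Cl)cc2C(=O)N1c1ccncc1`, 19%
compound 3, `O=C1c2c(Br)c(Br)c(Br)c(Br)c2C(=O)N1Cc1ccccn1`, 54%

In a functional assay on the whole organism (serum, strain Swiss albino) with Rattus norvegicus as the target, read by spectrophotometry, with a stated time of 14 days, at a dose of 10 mg/kg by the oral route (on this read-out higher numbers stand for more inhibition at the one dose given (going by the name of the read-out) and lower numbers for less inhibition), compound 2 stands lowest of the three numbers; compound 3 lies closer to it than compound 1 does, both beyond the scatter. Within the data shown here, the only measured step that touches the imide nitrogen directly is a number 39 percentage points lower from compound 1 to compound 2 (beyond the scatter), where pyridin-4-yl entered in place of pyrimidin-2-yl. Among the measured compounds shown here, compound 3 carries a pyridin-2-ylmethyl group on a different core and gives 54%; no single-point step to it is available, so its value is noted only as a second case of a high reading with a two-position heteroaryl.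

Compound 4, `O=C1c2cc(Cl)c(Cl)cc2C(=O)N1c1ccccn1`, differs from compound 2 as follows: pyridin-2-yl in place of pyridin-4-yl on an amide-type nitrogen in a ring. Pyridin-2-yl shares its point of attachment by name with the pyrimidin-2-yl of compound 1, whereas pyridin-4-yl is the group that brought the drop. Partial recovery toward compound 1 is therefore the working expectation, tempered by the fact that one step is the whole evidence.

Compound 4 is expected to give about 45% in this assay, within 25% to 62%. The expected step is a number 26 percentage points higher from compound 2 to compound 4 (beyond the scatter), an increase beyond the scatter.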

Compound 4, a percentage reported as inhibition, in the whole organism at one dose (the size of the read-out at that dose, not a potency): 17%
Compound 4: the middle estimate sits 28 percentage points above what was measured, and the stated range ends above it.
By their numbers in this assay, from the lowest: compounds 4 and 2 (each within the scatter of the next); then compounds 3 and 1 (each within the scatter of the next).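

Exchanging pyridin-4-yl for pyridin-2-yl on the amide-type nitrogen in a ring gives a number 2 percentage points lower from compound 2 to compound 4 (within the scatter) in this assay, so the two pyridinyl isomers cannot be told apart at this position on this read-out. The low reading is therefore not specific to pyridin-4-yl, since pyrimidin-2-yl to pyridin-2-yl gives a number 41 percentage points lower from compound 1 to compound 4 (beyond the scatter) and sits alongside the earlier a number 39 percentage points lower from compound 1 to compound 2 (beyond the scatter) as a second large step of the same direction. With the shared core held fixed, the high reading so far belongs to the pyrimidin-2-yl group alone, and neither pyridinyl group retains it.

Still open, going by these compounds, is whether a pyrazin-2-yl, a pyrimidin-5-yl or a plain phenyl group on this nitrogen would read with compound 1 or with the pyridinyl pair, or where a pyridin-2-ylmethyl group would fall on the shared core, and the steps to compound 3 cannot be read because it differs from the others in more than one place. Nothing on hand bears on why the pyrimidin-2-yl group stands apart from both pyridinyl groups.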